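The source may report more compounds than this note shows. Statements on the series, on what has been measured and on what is new or still open speak of the compounds shown alone.

a physicochemical assay for solubility, measured as kinetic solubility, with a stated time of 15 h, at pH 7.4 (a lower number here means a less soluble compound, a higher number a more soluble compound), has been measured for three compounds that share one core. Compound 1 (`Cc1cccc(-c2ccc(O[C@H]3O[C@H](CO)[C@@H](O)[C@H](O)[C@@H]3O)c(Cl)c2)c1`) gives 7.1 ug/mL, compound 2 (`OC[C@H]1O[C@H](Oc2ccc(-c3ccc(C(F)(F)F)cc3)cc2Cl)[C@@H](O)[C@@H](O)[C@@H]1O`) gives 22 ug/mL, and compound 3 (`Cc1ccc(-c2ccc(O[C@H]3O[C@H](CO)[C@@H](O)[C@H](O)[C@@H]3O)c(Cl)c2)cc1`) gives 7.4 ug/mL. Compound 3 therefore stands level with compound 1, within the scatter, and well under compound 2.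

The next compound is compound 4 (`O=[N+]([O-])c1cccc(-c2ccc(O[C@H]3O[C@H](CO)[C@@H](O)[C@H](O)[C@@H]3O)c(Cl)c2)c1`), which has 3-nitrophenyl in place of 4-methylphenyl on an aromatic carbon, meta to a chloro group and para to a large group: 3-nitrophenyl in place of 4-methylphenyl on an aromatic carbon.

Going by the values given here, two measured steps bear on this change. Exchanging 3-methylphenyl for 4-methylphenyl gives a 1.0-fold higher number from compound 1 to compound 3 (0.02 log units; within the scatter), so that shift of the methyl group left the number unmoved. Exchanging trifluoromethyl for methyl gives a 3.0-fold lower number from compound 2 to compound 3 (0.47 log units; beyond the scatter), a modest step and the only one beyond the scatter. Among the compounds with values here, no measured compound carries 3-nitrophenyl, so both steps are only loose guides. The compound 2 step does show that replacing the methyl group on this aryl substituent can raise the number by a modest amount. A small rise is therefore expected, and it may well stay inside the scatter: the expected change is a 1.6-fold higher number from compound 3 to compound 4 (0.21 log units; within the scatter). For compound 4 the estimate is 12 ug/mL, with an expected range from 5 ug/mL to 30 ug/mL.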

Compound 4, solubility: 23 ug/mL
Compound 4: the middle estimate sits 1.9-fold (0.28 log units) below what was measured, and the stated range covers the measured number.
By their numbers in this assay, from the lowest: compounds 1 and 3 (each within the scatter of the next); then compounds 2 and 4 (each within the scatter of the next).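

Nitro in place of methyl on the same aromatic carbon gives a 3.2-fold higher number from compound 1 to compound 4 (0.51 log units; beyond the scatter), and 3-nitrophenyl in place of 4-methylphenyl gives a 3.1-fold higher number from compound 3 to compound 4 (0.49 log units; beyond the scatter), so in this assay both methyl-bearing compounds lead to compound 4 by steps beyond the scatter. Moving the methyl between 3-methylphenyl and 4-methylphenyl had left the number within the scatter, whereas changing the group itself moves it, and a rise from a methyl-bearing compound is no longer seen only with the trifluoromethyl group of compound 2. The data given here offer no measurement that accounts for this rise.

The compounds shown carry nitro at one position only, so it remains open whether the number depends on where that group sits on the aryl ring. From the compounds shown here alone, it is also open whether other groups at this place, such as an amine, a carboxylic acid or a nitrile, would move the number as far as nitro does, or whether the rise is confined to the nitro and trifluoromethyl groups seen so far.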